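Branching the ketone chain: compound 2 to compound 4

A few compounds are considered here, and "the series" means these few. Any claim that something is new, unique, unknown or untested is made for them only; others in the source may bear on it.

Working notes on the series. It comprises compound 1 `Cc1c(OCCCCOc2ccc(C(=O)O)cc2)ccc(C(=O)CC2CCCC2)c1O`, compound 2 `CCCC(=O)c1ccc(OCCCCOc2cc(C(=O)O)ccc2OC)c(C)c1O`, compound 3 `Cc1cc(OCCCCOc2ccc(C(=O)CC3CCCC3)c(O)c2C)ccc1C(=O)O` and the as yet unmeasured compound 4 `COc1ccc(C(=O)O)cc1OCCCCOc1ccc(C(=O)C(C)C)c(O)c1C`. In an assay on HEK293 cells for positive allosteric modulation of metabotropic glutamate receptor 2 (Rattus norvegicus), read by thallium flux, with a stated time of 2.5 min (on this read-out higher numbers stand for an effect only at larger amounts of compound and lower numbers for an effect already at smaller amounts), compound 1 gives 824 nM, compound 3 gives 564 nM and compound 2 gives 103 nM. Compound 2 thus stands lowest of the three numbers, with compound 3 nearest and compound 1 furthest, both gaps beyond the scatter. Going by the values given here, the only single-point step measured so far, a 1.5-fold lower number from compound 1 to compound 3 (0.16 log units; within the scatter), concerns methyl in place of hydrogen on an aromatic carbon and lies within the scatter.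

Compound 4 differs from compound 2 by isopropyl in place of propyl on a carbonyl carbon; the same difference, cut one bond further out, reads propylcarbonyl to isopropylcarbonyl. Among the compounds with values here, no measured step bears on this change: the step from compound 1 to compound 3 sits on an aromatic carbon, not on the carbonyl carbon, and says nothing about the ketone chain. With no relevant comparison, the expectation for compound 4 in this assay is a step of a 1.1-fold higher number from compound 2 to compound 4 (0.03 log units; within the scatter), that is, none beyond the scatter. Compound 4 is therefore estimated at 110 nM in this assay, with a range from 45 nM to 280 nM.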

Compound 4, half-maximal effective concentration: 116 nM
For compound 4 the middle estimate is 1.1-fold (0.02 log units) below the measured one, and the stated range covers the measured number.
By their numbers in this assay, from the lowest: compounds 2 and 4 (each within the scatter of the next); then compounds 3 and 1 (each within the scatter of the next).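

In this assay, going by these compounds alone, the first measured change on the ketone chain gives a 1.1-fold higher number from compound 2 to compound 4 (0.05 log units; within the scatter), with isopropyl in place of propyl on a carbonyl carbon. The earlier compounds shown here offered no reading at this position, and this pair now shows that rearranging these three carbons from a straight chain to a branched one, with the heavy-atom count unchanged, produces no shift beyond the scatter. Nothing available explains why this change leaves the number within the scatter.

Still open, going by these compounds, is whether a bulkier branched group such as tert-butyl, or a small ring such as cyclopropyl, on the same carbonyl carbon would also stay within the scatter. A single pair also cannot show whether the propyl to isopropyl change would read the same way on the core of compound 1.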